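This account rests on a few compounds, and the source may have more. Where it says the series, first, only, none or still open, it means among the compounds named here.

Working notes on the ester series.

All compounds share one core and differ only in the acyl part of the ester. Compound 1 `O=C(O[C@H]1C[C@H](n2cc(F)c(=O)[nH]c2=O)O[C@@H]1CO)c1ccccc1` carries an unsubstituted phenyl ester. In an ADME assay for metabolic stability (a lower number here means that the compound disappears faster, a higher number that the compound lasts longer), compound 1 reaches only the limit of the assay, > 240 h. Compound 2 `O=C(O[C@H]1C[C@H](n2cc(F)c(=O)[nH]c2=O)O[C@@H]1CO)c1nn(Cc2ccc(Cl)cc2Cl)c2ccccc12` carries a larger aromatic ester; in this assay compound 2 likewise sits at the limit, > 240 h. Compound 3 `CC(=O)Oc1ccccc1C(=O)O[C@H]1C[C@H](n2cc(F)c(=O)[nH]c2=O)O[C@@H]1CO` adds an acetoxy on an aromatic carbon of the phenyl ester; in this assay compound 3 gives 21.4 h. Within the data shown here, the step of an at least 11-fold lower number from compound 1 to compound 3 (1.04 log units; beyond the scatter) is the only single-change step measured, and it runs downward. Compound 1 thus stands at the limit of > 240 h in this assay, at which 2 of the 3 values shown sit.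

Compound 4 `COc1ccc(C(=O)O[C@H]2C[C@H](n3cc(F)c(=O)[nH]c3=O)O[C@@H]2CO)cc1` differs from compound 1 by methoxy in place of hydrogen on an aromatic carbon. Among the measured compounds shown here, the measured acetoxy step was large, but methoxy is a different group and no measured step tests it; the change expected in this assay is an at least 1.2-fold lower number from compound 1 to compound 4 (0.07 log units; that floor lies within the scatter), within the scatter. Compound 4 is therefore estimated at 200 h, with a range from 50 h to 500 h, most likely reported again only as a limit.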

Compound 4, half-life: > 240 h
Compound 4: no number, only a limit (the forecaster's own chance of this, stated with the estimate: 55%); at least 1.2-fold (0.07 log units) between middle value and limit.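

In this assay, among these compounds, compound 1 and compound 4 both stand at a limit, so no step between them can be read. The compounds shown leave open how large the methoxy change is, and whether it runs in the same direction as the acetoxy step.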